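Working notes: from compound 3 to compound 4

The source may report more compounds than this note shows. Statements on the series, on what has been measured and on what is new or still open speak of the compounds shown alone.

Values in a functional assay on Bel-7402 cells (Homo sapiens) for antiproliferative activity, read by MTT assay, with a stated time of 72 h (on this read-out higher numbers stand for weaker inhibition and lower numbers for stronger inhibition), are as follows
- compound 1 `C=C1C(=O)O[C@H]2[C@H]1CC/C(COC(=O)CCC(=O)NCCCCCCNC(=O)Cn1cc(F)c(=O)[nH]c1=O)=C\CC[C@@]1(C)O[C@@H]21` gives > 20000 nM as a limit
- compound 2 `C=C1C(=O)O[C@H]2[C@H]1CC/C(COC(=O)CCC(=O)N1CCN(C(=O)Cn3cc(F)c(=O)n(Cc4ccccc4)c3=O)CC1)=C\CC[C@@]1(C)O[C@@H]21` gives > 20000 nM as a limit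
- compound 3 `C=C1C(=O)O[C@H]2[C@H]1CC/C(COC(=O)Cn1cc(F)c(=O)n(Cc3ccc(F)cc3)c1=O)=C\CC[C@@]1(C)O[C@@H]21` gives 2730 nM as a number

For the measured compounds named here, compound 3 with 2730 nM is the only compound here that reads as a number. The other two compounds rest on the limit of > 20000 nM in this assay, at which 2 of the 3 values shown sit, and give no number.

Compound 4 `C=C1C(=O)O[C@H]2[C@H]1CC/C(COC(=O)Cn1cc(F)c(=O)n(Cc3c(F)cccc3F)c1=O)=C\CC[C@@]1(C)O[C@@H]21` has not yet been measured. Its change from compound 3 lies on a saturated chain carbon bound to an aromatic nitrogen, with 2,6-difluorophenyl in place of 4-fluorophenyl, and it counts as 2,6-difluorophenyl in place of 4-fluorophenyl on a saturated chain carbon bound to an aromatic nitrogen in full.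

Going by the values given here, no measured pair in this set isolates this position. The expectation therefore rests on compound 3 with 2730 nM as the nearest measured neighbour. In this assay the expected result is a 1.1-fold higher number from compound 3 to compound 4 (0.04 log units; within the scatter) and so no change beyond the usual scatter. For compound 4 the estimate is 3000 nM in that read-out, with an expected range from 1200 nM to 8000 nM around it.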

Compound 4, half-maximal inhibitory concentration: 4500 nM
The estimate for compound 4 lay 1.5-fold (0.18 log units) below the measured number; measured number inside the range.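

In this assay, 2,6-difluorophenyl in place of 4-fluorophenyl on a saturated chain carbon bound to an aromatic nitrogen gives a 1.6-fold higher number from compound 3 to compound 4 (0.22 log units; within the scatter). For the compounds shown here, this is the first measured pair that isolates this position, and it shows that the position takes this change with no shift beyond the usual scatter. Compound 4 also adds a second number to the series, while no step to the other compounds can be read: the limit of > 20000 nM in this assay, at which 2 of the 4 values shown sit.

Going by these compounds alone, the pair covers only two fluorinated phenyl groups, so it remains open how the number in this assay would respond to a phenyl ring carrying an amine or a carboxylic acid at this position. As far as these compounds go, it is equally open what a longer chain in place of the single saturated carbon would do.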